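Fused pyrimidine series: F508del correction, side-chain replacement

The source may hold more compounds than are shown below. What is called first, only, known or untested is meant among the compounds shown, and "the series" means these compounds.

Measured compounds:
compound 1 `CN(C)CCN1CCN(c2nc(-c3ccccn3)nc3c2CN(Cc2ccccc2)CC3)CC1`: 57%
compound 2 `COc1ccc(CN2CCc3nc(-c4ccccn4)nc(N4CCN(CCN(C)C)CC4)c3C2)cc1`: "not active" (no number reported)
compound 3 `CN(C)CCN1CCN(c2nc(-c3ccccn3)nc3c2CN(Cc2ccc(F)cc2)CC3)CC1`: "not active" (no number reported)

In an assay on A549 cells with Cystic fibrosis transmembrane conductance regulator variant F508del (Homo sapiens) as the target, read by fluorescence, with a stated time of 25 min (a lower number here means a smaller maximal response, a higher number a larger maximal response), compound 1 gives 57%. Compound 2 is recorded in this assay as "not active" (no number reported). Compound 3 stands with compound 2 at the bottom of the set: in this assay compound 3 is "not active" (no number reported), with no number attached, so its position rests on that entry alone.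

Compound 4 `CC(=O)NCCNc1nc(-c2ccccn2)nc2c1CN(Cc1ccc(F)cc1)CC2` has not been measured. Against compound 3 the change is (2-acetamidoethyl)amino in place of 4-(2-(dimethylamino)ethyl)piperazin-1-yl on an aromatic carbon. Among the compounds with values here, no step between measured compounds covers this change, and compound 3 itself carries no number, so the size and direction of the step to compound 4 in this assay cannot be set from the data; the one numbered point is compound 1 at 57%.

Compound 4 is expected to give a largest response of about 20% in this assay, estimated between 0% and 50%, with a real chance that only an inactive entry is reported.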

Compound 4, largest response reached (Emax), in percent of the reference or control that the assay uses: 44.3%
Estimate against measurement, compound 4: 24.3 percentage points below; the measured number falls inside the stated range.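

In this assay, within the data shown here, compound 3 carries no number, and no step from it to compound 4 can be read. No measured evidence bears on the response of compound 4.
Left open is how (2-acetamidoethyl)amino compares with 4-(2-(dimethylamino)ethyl)piperazin-1-yl where both carry numbers.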